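The source may report more compounds than this note shows. Statements on the series, on what has been measured and on what is new or still open speak of the compounds shown alone.

Of the compounds shown here, three have been measured: compound 1 `N#Cc1ccc(Nc2ncnc(OC3C4COCC3CN(C(=O)OC3CCC3)C4)c2F)c(Cl)c1`, compound 2 `CC1(OC(=O)N2CC3COCC(C2)C3Oc2ncnc(Nc3cccnc3Cl)c2F)CC1` and compound 3 `COCC1(OC(=O)N2CC3COCC(C2)C3Oc2ncnc(Nc3ccc(C#N)cc3F)c2F)CC1`, all built on the shared core and differing in the aromatic amine and in the group at the far end of the molecule. In a functional assay for agonist activity at Glucose-dependent insulinotropic receptor (Mus musculus), read by cAMP accumulation (a lower number here means a smaller maximal response, a higher number a larger maximal response), compound 1 gives 60%, compound 2 gives 84% and compound 3 gives 70%. Among these three numbers compound 3 stands second highest; its gap to compound 1 lies within the scatter, while its gap to compound 2 is beyond the scatter. Compound 4 `CCC1(OC(=O)N2CC3COCC(C2)C3Oc2ncnc(Nc3ccc(C#N)cc3F)c2F)CC1` has not yet been measured. The change from compound 3 to compound 4 is methyl in place of methoxy on a saturated chain carbon bound to a saturated ring carbon. Among the compounds with values here, no pair of measured compounds differs by a single change, so no step of this kind has been observed. The expectation for compound 4 in this assay is therefore no step beyond the scatter in either direction, and the estimated step is a number 2 percentage points higher from compound 3 to compound 4 (within the scatter). Compound 4 is expected to give 72%, with a range from 55% to 90%.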

Compound 4, largest response reached (reported as percent of maximum), in percent of the reference or control that the assay uses: 90%
Beside the measured number, compound 4's estimate is 18 percentage points below it, and the stated range covers the measured number.
By their numbers in this assay, from the lowest: compounds 1 and 3 (each within the scatter of the next); then compounds 2 and 4 (each within the scatter of the next).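

Within the data shown here, compound 3 and compound 4 give the first single change that can be read in this assay: methyl in place of methoxy on a saturated chain carbon bound to a saturated ring carbon gives a number 20 percentage points higher from compound 3 to compound 4 (beyond the scatter) with the rest of the molecule unchanged. The earlier compounds shown here each differed in more than one place, so they could not separate this position from the aromatic amine; now the position is seen to matter, with 1-ethylcyclopropyl giving the larger maximal response than 1-(methoxymethyl)cyclopropyl. Nothing at hand accounts for the size or direction of this step.

Going by these compounds, whether the same change holds with the aromatic amines of compound 1 and compound 2 remains open. So does the response with a hydroxyl group, an amine or a longer chain such as propyl at this place.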